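This account rests on a few compounds, and the source may have more. Where it says the series, first, only, none or still open, it means among the compounds named here.

In a functional assay on A549 cells (Homo sapiens) for inhibition, read by sulforhodamine B assay, with a stated time of 72 h (a higher number here means a weaker inhibitor of growth, a lower number a stronger inhibitor of growth), compound 1 (`CN1CCN(C(=O)/C=C/c2ccncc2-c2ccc3ccccc3c2)CC1`) gives > 10000 nM as a limit of the assay and not as a number. Its true position is therefore unknown. Among the compounds with values here, compound 2 (`CNC(=O)/C=C/c1ccncc1-c1ccc2cc[nH]c2c1`) reads 7840 nM in this assay and is the only true number so far, but it differs from compound 1 in more than one place and gives no clean step. Compound 3 (`CCOC(=O)/C=C/c1ccncc1-c1ccc2ccccc2c1`) has not yet been measured. From compound 1 to compound 3 the change is ethoxy in place of 4-methylpiperazin-1-yl on a carbonyl carbon, with the shared core untouched. Within the data shown here, no measured step gauges this change in this assay and only a small shift toward stronger growth inhibition is expected, perhaps none beyond the scatter. With compound 2 at 7840 nM as the only numeric anchor, a weak inhibitor is still expected. The expected step is an at least 1.2-fold lower number from compound 1 to compound 3 (0.09 log units; that floor lies within the scatter) and it remains uncertain given the limit at its start. For compound 3 the estimate is 8000 nM with an expected range from 2500 nM to 20000 nM and a real chance of another limit.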

Compound 3, concentration for 50% growth inhibition: 5380 nM
Estimate against measurement, compound 3: 1.5-fold (0.17 log units) above; low and high end bracket the measured number.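

With ethoxy in place of 4-methylpiperazin-1-yl on a carbonyl carbon, the shared core gives a real reading in this assay: compound 3 gives 5380 nM, so this place in the series can carry a group without a ring and still yield a number. Compound 1 gives > 10000 nM, which is a limit of the assay and not a number. The change can be read only as a floor, an at least 1.8-fold lower number from compound 1 to compound 3 (0.26 log units; that floor lies within the scatter), and its true size stays unknown because the step starts from a limit: the limit of > 10000 nM in this assay, at which 1 of the 3 values shown sits.

The compounds shown do not tell whether any shift follows from the arrival of ethoxy or from the loss of 4-methylpiperazin-1-yl, and a single step cannot separate the two. A carboxylic acid, a longer alkoxy chain such as butoxy, or a small amine such as dimethylamino on the same carbonyl carbon would show whether readings in this assay move with the group at this place at all.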